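The source may report more compounds than this note shows. Statements on the series, on what has been measured and on what is new or still open speak of the compounds shown alone.

In a functional assay on K562 cells (Homo sapiens) for cytotoxicity, read by trypan blue exclusion, with a stated time of 96 h (on this read-out lower numbers stand for stronger inhibition and higher numbers for weaker inhibition), compound 1 `COC(=O)C(Nc1cc(CS(=O)(=O)/C=C/c2c(OC)cc(OC)cc2OC)ccc1OC)c1ccccc1` gives 30 nM, compound 2 `COC(=O)C(Nc1cc(CS(=O)(=O)/C=C/c2c(OC)cc(OC)cc2OC)ccc1OC)c1ccc(F)cc1` gives 800 nM and compound 3 `COC(=O)C(Nc1cc(CS(=O)(=O)/C=C/c2c(OC)cc(OC)cc2OC)ccc1OC)c1ccc(Cl)cc1` gives 200 nM, which makes compound 3 the second highest of the three numbers. Compound 4 `COc1cc(OC)c(/C=C/S(=O)(=O)Cc2ccc(OC)c(NC(C)(C)C(=O)O)c2)c(OC)c1` has not been measured. It differs from compound 3 as follows: 1-carboxy-1-methylethyl in place of (4-chlorophenyl)(methoxycarbonyl)methyl on a nitrogen on an aromatic ring. For the measured compounds named here, three measured steps bear on this change: a 27-fold higher number from compound 1 to compound 2 (1.43 log units; beyond the scatter), a 6.7-fold higher number from compound 1 to compound 3 (0.82 log units; beyond the scatter) and a 4.0-fold lower number from compound 2 to compound 3 (0.60 log units; beyond the scatter). All three are changes on the aromatic ring of the group that leaves. They range from modest to large, and each lies beyond the scatter. None of them replaces the whole group, so they show that the number moves with changes in this part of the molecule but give no direction for the present change. From the compounds shown here alone, the central expectation is therefore no step beyond the scatter, with a modest or large move in either direction still open. The expected step is a 1.5-fold higher number from compound 3 to compound 4 (0.18 log units; within the scatter). For compound 4 the estimate is 300 nM, with an expected range of 40 nM to 2500 nM.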

Compound 4, half-maximal inhibitory concentration: 7.5 nM
Compound 4: the middle estimate sits 40-fold (1.60 log units) above what was measured, and the stated range ends above it.
By their numbers in this assay, from the lowest: compound 4; then compound 1; then compound 3; then compound 2.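

On the nitrogen in this assay, the 1-carboxy-1-methylethyl group, which has no ring, gives a 27-fold lower number from compound 3 to compound 4 (1.43 log units; beyond the scatter) and a 110-fold lower number from compound 2 to compound 4 (2.03 log units; beyond the scatter), and it also surpasses the unsubstituted phenyl parent with a 4.0-fold lower number from compound 1 to compound 4 (0.60 log units; beyond the scatter). The earlier compounds shown here changed only a halogen on the ring of the leaving group, so they left open whether that ring and its methoxycarbonyl group were needed; compound 4 shows that neither is required for the lowest number of the four compounds. No measurement here explains this drop.

The ring, the ester and the substitution on the carbon attached to nitrogen all change together, so their separate contributions remain unresolved. The methyl ester 1-(methoxycarbonyl)-1-methylethyl and the unbranched carboxymethyl group would begin to separate the carboxylic acid from the two methyl groups.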